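Ring Size at the Aminopyridine: From Pyrrolidine to Dimethylpiperidine

The compounds below may be only part of what the source reports. "The series", "measured", "known", "first", "only" and "open" are said of these compounds alone.

Compound 1 `CC(C(=O)NCc1ccc(C(F)(F)F)nc1N(C)C)c1ccc(NS(C)(=O)=O)c(F)c1`: 19.1 nM
Compound 2 `CC(C(=O)NCc1ccc(C(F)(F)F)nc1N1CCCC1)c1ccc(NS(C)(=O)=O)c(F)c1`: 0.6 nM

In a functional assay on CHO-K1 cells for antagonist activity at transient receptor potential cation channel subfamily V member 1 (Homo sapiens), read by FLIPR (a lower number here means a stronger inhibitor, a higher number a weaker inhibitor), compound 2 gives 0.6 nM, the lowest of the two numbers, while compound 1 gives 19.1 nM. Compound 3 `CC(C(=O)NCc1ccc(C(F)(F)F)nc1N1CCC(C)(C)CC1)c1ccc(NS(C)(=O)=O)c(F)c1` carries 4,4-dimethylpiperidin-1-yl in place of pyrrolidin-1-yl on an aromatic carbon. For the measured compounds named here, the only measured step that bears on this change is a 32-fold lower number from compound 1 to compound 2 (1.50 log units; beyond the scatter), where a cyclic amine in place of an open one brought a large gain. As far as these compounds go, whether a larger ring holds that gain is unknown, so an estimate near compound 2 with a wide range is expected: a 1.7-fold higher number from compound 2 to compound 3 (0.22 log units; within the scatter), giving compound 3 an expected value of 1 nM, between 0.2 nM and 6 nM.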

Compound 3, inhibition constant: 0.3 nM
Compound 3: middle estimate off by 3.3-fold (0.52 log units), on the high side; measured number inside the range.
By their numbers in this assay, from the lowest: compounds 3 and 2 (each within the scatter of the next); then compound 1.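

In this assay, placing 4,4-dimethylpiperidin-1-yl where pyrrolidin-1-yl stood gives a 2.0-fold lower number from compound 2 to compound 3 (0.30 log units; within the scatter) and so shows that this position accepts a six-membered ring with more heavy atoms while keeping the gain over dimethylamino. Measured against the open amine, the new ring gives a 64-fold lower number from compound 1 to compound 3 (1.80 log units; beyond the scatter) at this same position. No measurement here explains why these cyclic amines differ so much from dimethylamino.

Still open, as far as these compounds go, is whether the two methyl groups matter, which plain piperidin-1-yl would show. Also open, from the compounds shown here alone, is how a smaller azetidin-1-yl ring or a morpholin-4-yl ring, with its added oxygen, would fare here.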